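A few compounds are considered here, and "the series" means these few. Any claim that something is new, unique, unknown or untested is made for them only; others in the source may bear on it.

Working notes on the series: in an ADME assay on MT4 cells (Homo sapiens) for cytotoxicity, read by MTT assay, with a stated time of 5 days (on this read-out lower numbers stand for higher toxicity in this test and higher numbers for lower toxicity in this test), compound 1 (`Cc1cc(C)cc(S(=O)(=O)c2c(C(=O)N[C@H]3CCNC3)[nH]c3ccc(Cl)cc23)c1`) gives 10000 nM. Compound 2 (`Cc1cc(C)cc(S(=O)(=O)c2c(C(=O)NC3CN(Cc4ccccc4C#N)C3)[nH]c3ccc(Cl)cc23)c1`) gives > 234000 nM, which is a limit and not a number. Compound 3 (`Cc1cc(C)cc(S(=O)(=O)c2c(C(=O)NC3CN(CC(N)=O)C3)[nH]c3ccc(Cl)cc23)c1`) differs from compound 2 by one change: carbamoyl in place of 2-cyanophenyl on a saturated chain carbon bound to an amine nitrogen in a ring. Among the compounds with values here, no measured step covers this change, and compound 1 at 10000 nM is the only true number in hand. In this assay the expected step is an at least 2.3-fold lower number from compound 2 to compound 3 (0.36 log units; beyond the scatter), a moderate fall in the number. For compound 3 the expected value is 100000 nM, with an estimated range of 20000 nM to 300000 nM.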

Compound 3, half-maximal cytotoxic concentration: 25500 nM
Compound 3: middle estimate off by 3.9-fold (0.59 log units), on the high side; measured number inside the range.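

In this assay, carbamoyl in place of 2-cyanophenyl gives an at least 9.1-fold lower number from compound 2 to compound 3 (0.96 log units; beyond the scatter), so this place on the chain does move the read-out, and it yields a true number on the azetidine. As far as these compounds go, the upper end of that step stays unknown, as compound 2 has only a limit and not a number: the limit of > 234000 nM in this assay, at which 1 of the 3 values shown sits. Set against the pyrrolidin-3-yl amide, 1-(carbamoylmethyl)azetidin-3-yl gives a 2.6-fold higher number from compound 1 to compound 3 (0.41 log units; beyond the scatter), a modest step.

A plain benzyl would show whether the step follows the phenyl ring or the nitrile. From the compounds shown here alone, a carboxylic acid in place of carbamoyl, or a longer chain, remains open.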